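A few compounds are considered here, and "the series" means these few. Any claim that something is new, unique, unknown or untested is made for them only; others in the source may bear on it.

Working notes on the series, read in a functional assay on cells (T-cell, Mus musculus) for inhibition; on this read-out lower numbers stand for stronger inhibition and higher numbers for weaker inhibition. Among the measured compounds shown here, compound 1 `Nc1nc(N)c2nc(CNc3ccc(C(=O)N[C@@H](CC(F)C(=O)O)C(=O)O)cc3F)cnc2n1` gives 0.0094 ug/mL, its only single number here, and it has one further entry without a single number. Compound 2 `Cc1cc(C(=O)N[C@@H](CC(F)C(=O)O)C(=O)O)ccc1NCc1cnc2nc(N)nc(N)c2n1` gives 0.0078 ug/mL; 0.0107 ug/mL (2 entries) in this assay, which places the two compounds within the scatter of each other. Compound 3 `Nc1nc(N)c2nc(CNc3ccc(C(=O)N[C@@H](CC(F)C(=O)O)C(=O)O)cc3Br)cnc2n1` has not yet been measured. It differs from compound 1 as follows: bromo in place of fluoro on an aromatic carbon, ortho to a large group and meta to a large group. For the measured compounds named here, no measured pair isolates this exchange, so the only guide is how close compound 1 at 0.0094 ug/mL lies to compound 2. In this assay no step beyond the scatter is expected, in either direction. The expected move is a 1.2-fold higher number from compound 1 to compound 3 (0.07 log units; within the scatter). Compound 3 is estimated at 0.011 ug/mL, with an expected range of 0.004 ug/mL to 0.03 ug/mL.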

Compound 3, half-maximal inhibitory concentration: 0.0021 ug/mL
For compound 3 the middle estimate is 5.2-fold (0.72 log units) above the measured one; measured number below the stated range.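

In this assay, bromo in place of fluoro on this aromatic carbon, ortho to a large group and meta to a large group, gives a 4.5-fold lower number from compound 1 to compound 3 (0.65 log units; beyond the scatter). Among the compounds shown here, this is the first matched pair at this position, and it shows that the position responds to the identity of the halogen, even though the exchange leaves the heavy-atom count unchanged and adds no hydrogen-bond donor or acceptor. The step also exceeds the spread between repeat readings of a single compound in this series: the several entries of compound 2 in this assay, 0.0078 ug/mL; 0.0107 ug/mL (2 entries)

With a single pair at this position, no trend across the halogens can be read, and the reason for the step remains unknown. Chloro or iodo on the same carbon would show whether the number keeps falling along the halogens or whether bromo stands alone.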